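Cytotoxicity notes: furan-3-yl replaced by (4-methoxyphenyl)amino

This account rests on a few compounds, and the source may have more. Where it says the series, first, only, none or still open, it means among the compounds named here.

The series is built on a shared core carrying an aryl group and a sulfur-linked benzyl arm. Compound 1 `COc1ccc(-c2nc(CSc3cccc(Br)c3)nc3ccsc23)cn1` is read in an ADME assay on cells (Homo sapiens) for cytotoxicity, read by resazurin assay, with a stated time of 5 days; on this read-out higher numbers stand for lower toxicity in this test and lower numbers for higher toxicity in this test. In this assay compound 1 returns only a limit, > 50000 nM. Compound 3 `COc1ccc(-c2nc(CSc3cccc(Cl)c3Cl)nc3ccsc23)cn1` likewise returns only a limit in this assay, > 50000 nM. The step that the two limits leave unreadable from compound 1 to compound 3 therefore cannot be read. Compound 2 `O=S(=O)(Cc1nc(-c2ccoc2)c2sccc2n1)c1cccc(Cl)c1` stands in the same place: in this assay compound 2 gives only a limit, > 50000 nM. Taken together, the evidence is the limit of > 50000 nM in this assay, at which 3 of the 3 values shown sit, so no measured step in the series is readable.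

Compound 4 `COc1ccc(Nc2nc(CS(=O)(=O)c3cccc(Cl)c3)nc3ccsc23)cc1` differs from compound 2 by (4-methoxyphenyl)amino in place of furan-3-yl on an aromatic carbon. Within the data shown here, no measured pair tracks this change, and none of the three steps available gives a readable size. With every measured compound sitting at the limit, the expectation for compound 4 is that the step that the limit leaves unreadable from compound 2 to compound 4 stays within the scatter. Compound 4 is thus estimated at 60000 nM in this assay, with a range from 15000 nM to 200000 nM, most likely reported again as a limit.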

Compound 4, half-maximal cytotoxic concentration: 60000 nM
The estimate for compound 4 equals the measured number at the digits printed; low and high end bracket the measured number.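

The step between compound 2 and compound 4 cannot be read, as compound 2 gives only a limit: the limit of > 50000 nM in this assay, at which 3 of the 4 values shown sit. The compounds shown leave open whether any change on the shared core brings the half-maximal cytotoxic concentration down far enough to give a step of readable size.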